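The source may report more compounds than this note shows. Statements on the series, on what has been measured and on what is new or still open speak of the compounds shown alone.

In an ADME assay on microsomes from liver (Mus musculus) for metabolic stability, read by LC-MS, using NADPH, with a stated time of 60 min, tested at 10 uM (on this read-out lower numbers stand for a shorter-lived compound and higher numbers for a longer-lived compound), compound 1 `CCN(CC)S(=O)(=O)c1ccc(S(=O)(=O)N2CCC[C@@H](C(=O)N3CCC(F)(F)CC3)C2)cc1` gives 0.0433 h, the lowest of the three numbers measured. Compound 2 `O=C([C@@H]1CCCN(S(=O)(=O)c2ccc(S(=O)(=O)C3CCC3)cc2)C1)N1CCC(F)(F)CC1` gives 0.733 h and compound 3 `O=C([C@@H]1CCCN(S(=O)(=O)c2ccc(S(=O)(=O)N3CC[C@@H](O)C3)cc2)C1)N1CCC(F)(F)CC1` gives 0.437 h. The measured steps of a 17-fold higher number from compound 1 to compound 2 (1.23 log units; beyond the scatter) and a 10-fold higher number from compound 1 to compound 3 (1.00 log units; beyond the scatter) both change the group on the sulfonyl sulfur, while the step of a 1.7-fold lower number from compound 2 to compound 3 (0.22 log units; within the scatter) stays within the scatter. Compound 4 `CCN(CC)S(=O)(=O)c1ccc(S(=O)(=O)N2CCC[C@@H](C(=O)NC3COC3)C2)cc1` keeps the sulfonyl group of compound 1 and differs at the amide instead: (oxetan-3-yl)amino in place of 4,4-difluoropiperidin-1-yl on a carbonyl carbon. Within the data shown here, none of the measured steps touches the carbonyl side, so none of them bears directly on this change, and no direction can be read from them. The half-life is therefore expected to move only a little, as a step of a 2.3-fold higher number from compound 1 to compound 4 (0.36 log units; beyond the scatter). For compound 4 the estimate is 0.1 h, between 0.03 h and 0.4 h.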

Compound 4, half-life: 0.452 h
Compound 4: the middle estimate sits 4.5-fold (0.66 log units) below what was measured; measured number outside the range, above it.
By their numbers in this assay, from the lowest: compound 1; then compounds 3, 4 and 2 (each within the scatter of the next).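

The carbonyl side of the molecule also matters for half-life: in this assay, (oxetan-3-yl)amino in place of 4,4-difluoropiperidin-1-yl gives a 10-fold higher number from compound 1 to compound 4 (1.02 log units; beyond the scatter) while the diethylamino group stays in place. Earlier, only changes on the sulfonyl sulfur had moved the number. No evidence at hand explains this shift. From the compounds shown here alone, it remains open whether the ring oxygen or the amide hydrogen matters, which a cyclobutylamino or morpholin-4-yl group on that carbonyl carbon could help separate. Also open, going by these compounds, is whether this gain would add to that from cyclobutyl on the sulfonyl sulfur.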